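Cytotoxicity notes on an isoamyl-benzimidazole series

The compounds below may be only part of what the source reports. "The series", "measured", "known", "first", "only" and "open" are said of these compounds alone.

Measured so far:
compound 1 `CC(=O)NCc1ccc2c(c1)nc(Cn1c(=O)n(C(C)C)c3ccccc31)n2CCC(C)C` — 178000 nM
compound 2 `C=C(C)n1c(=O)n(Cc2nc3cc(/C(N)=N\O)ccc3n2CCC(C)C)c2ccccc21` — 3470 nM
compound 3 `CC(C)CCn1c(Cn2c(=O)n(C(C)C)c3ccccc32)nc2ccc(CO)cc21` — 81600 nM

All three share the same core and were run in an ADME assay on HEp-2 cells (Homo sapiens) for cytotoxicity; on this read-out lower numbers stand for higher toxicity in this test and higher numbers for lower toxicity in this test. Compound 1 gives 178000 nM, the highest number of the three, and thus the least toxic in this test. Compound 3, at 81600 nM, lies a step below it that is beyond the usual scatter, and compound 2, at 3470 nM, lies far below both. Since compounds 2 and 3 differ from compound 1 in more than one place, only their values can be compared; no single change can be credited.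

The next compound, compound 4 `CC(C)CCn1c(Cn2c(=O)n(C(C)C)c3ccccc32)nc2cc(C(N)=O)ccc21`, differs from compound 1 in one place only: carbamoyl in place of acetamidomethyl on an aromatic carbon. The group that enters carries the same count of hydrogen-bond donors and acceptors as the one that leaves, but is shorter.

Among the compounds with values here, no measured pair shows this exact change. From compound 3, whose value 81600 nM sits below compound 1 with a smaller polar substituent at a similar position, a modest step downward in this assay is expected, possibly at the edge of the scatter. The step from compound 1 to compound 4 is estimated at a 1.8-fold lower number from compound 1 to compound 4 (0.25 log units; within the scatter). Compound 4 is expected to give about 100000 nM, with a range from 35000 nM to 250000 nM.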

Compound 4, half-maximal cytotoxic concentration: 23400 nM
For compound 4 the middle estimate is 4.3-fold (0.63 log units) above the measured one; the whole stated range lies above it.
By their numbers in this assay, from the lowest: compound 2; then compound 4; then compound 3; then compound 1.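

In this assay, within the data shown here, the exchange of acetamidomethyl for carbamoyl gives a 7.6-fold lower number from compound 1 to compound 4 (0.88 log units; beyond the scatter) and is the first step that can be tied to a single place. It shows that the number responds to what this aromatic carbon carries, even though the entering and leaving groups have the same counts of hydrogen-bond donors and acceptors and neither contains a ring or a net charge. Matching those counts is therefore not enough to keep the number at the level of compound 1 in this series, and the entering group differs in being shorter, with fewer heavy atoms, although no measurement on hand explains the step.

One step cannot separate the effect of shortening the group from that of attaching the carbonyl directly to the aromatic carbon, and it gives no trend along a series of substituents. A carboxylic acid or an aminomethyl group at this place, or a longer chain ending in carbamoyl, would show whether the number follows the length of the group or the nature of its end.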